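The compounds below may be only part of what the source reports. "The series", "measured", "known", "first", "only" and "open" are said of these compounds alone.

Measured compounds:
- compound 1, `CCOC(=O)/C(C#N)=C/c1c[nH]cn1`: 33%
- compound 2, `NC/C(=C\c1ccoc1)C(=O)O`: -1.5%
- compound 3, `CCOC(=O)/C(C#N)=C/c1cc2ccccc2[nH]1`: 88.4%

All three were tested in a functional assay on the whole organism (strain CD1) for inhibition, with Mus musculus as the target, with stated times of 15 min and 20 min, at a dose of 10 mg/kg by the subcutaneous route; a higher number here means more inhibition at the dose given (going by the name of the read-out), a lower number less inhibition. Compound 3 stands highest of the three numbers: against compound 1 it is higher by a gap beyond the scatter, and against compound 2, the furthest, by a still wider gap, also beyond the scatter. For the measured compounds named here, no pair among the measured compounds differs in only one place, so no single-change step has been read off within this set.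

Compound 4, `N#C/C(=C\c1cc2ccccc2[nH]1)C(=O)Nc1ccccc1`, is the next compound for this assay. It differs from compound 3 in one place: anilino in place of ethoxy on a carbonyl carbon. Ethoxy leaves and anilino enters on the carbonyl carbon whose other neighbour is the double-bonded chain carbon; the rest of compound 3 is kept.

Going by the values given here, no measured step of this kind exists here, so the size of the step from compound 3 to compound 4 is not anchored by data. Because compound 3 gives 88.4%, near the top of the scale, the room upward is small and the expected direction is downward or level. A moderate decrease is expected, a number 23.4 percentage points lower from compound 3 to compound 4 (beyond the scatter), without confidence that it exceeds the scatter. Compound 4 is estimated at 65%, within a range of 25% to 95%.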

Compound 4, a percentage reported as inhibition, in the whole organism at one dose (the size of the read-out at that dose, not a potency): 52%
Beside the measured number, compound 4's estimate is 13 percentage points above it; the measured number falls inside the stated range.
By their numbers in this assay, from the lowest: compound 2; then compound 1; then compound 4; then compound 3.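

In this assay, the carbonyl carbon whose other neighbour is the double-bonded chain carbon now has its first single-change reading: anilino in place of ethoxy gives a number 36.4 percentage points lower from compound 3 to compound 4 (beyond the scatter), so the read-out at this dose depends on the group held at this position. The ethoxy group is nevertheless not essential for inhibition in this series, since compound 4 still gives 52% with anilino in that place. Nothing available here bears on why the step has this size.

A single replacement cannot separate the contribution of the aromatic ring in anilino from that of its nitrogen and the amide hydrogen, so a methylamino group or a benzyloxy group on the same carbonyl carbon would be the informative comparisons, with a carboxylic acid in that place as a further open case. As far as these compounds go, it also remains open whether a step of this size would carry over to the core of compound 1, as the reading so far comes from a single pair sharing one core.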